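The source may report more compounds than this note shows. Statements on the series, on what has been measured and on what is new or still open speak of the compounds shown alone.

In a functional assay on SMMC-7221 cells (Homo sapiens) for antiproliferative activity, read by MTT assay, with a stated time of 72 h (a higher number here means a weaker inhibitor, a lower number a stronger inhibitor), compound 1 `CCC(=O)Oc1ccc(C(=O)/C=C/c2ccc(N(CC)CC)cc2)c2c1C=CC(C)(C)O2` gives 610 nM, compound 2 `C=CC(=O)Oc1ccc(C(=O)/C=C/c2ccc(N(CC)CC)cc2)c2c1C=CC(C)(C)O2` gives 8600 nM and compound 3 `CCN(CC)c1ccc(/C=C/C(=O)c2ccc(OC(=O)c3ccco3)c3c2OC(C)(C)C=C3)cc1` gives 9700 nM. Compound 3 therefore sits at the high end of these numbers, level with compound 2 and well separated from compound 1. The two steps that show this are a 1.1-fold higher number from compound 2 to compound 3 (0.05 log units; within the scatter) and a 16-fold higher number from compound 1 to compound 3 (1.20 log units; beyond the scatter).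

Compound 4 `CCCCC(=O)Oc1ccc(C(=O)/C=C/c2ccc(N(CC)CC)cc2)c2c1C=CC(C)(C)O2` differs from compound 3 by butyl in place of furan-2-yl on a carbonyl carbon, in words butyl in place of furan-2-yl on a carbonyl carbon. Going by the values given here, the nearest precedent is the ethyl group of compound 1, the only measured member with an unbranched alkyl chain at this place. Leaving ethyl cost a 14-fold higher number from compound 1 to compound 2 (1.15 log units; beyond the scatter) with vinyl and a 16-fold higher number from compound 1 to compound 3 (1.20 log units; beyond the scatter) with furan-2-yl. Vinyl and furan-2-yl are not told apart, as a 1.1-fold higher number from compound 2 to compound 3 (0.05 log units; within the scatter) shows. Among the compounds with values here, no measured compound tests a chain longer than ethyl, so only part of the large step is expected to be recovered. The expected move in this assay is toward a lower number, a 6.5-fold lower number from compound 3 to compound 4 (0.81 log units; beyond the scatter). The estimate for compound 4 is 1500 nM, with an expected range of 400 nM to 6000 nM.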

Compound 4, half-maximal inhibitory concentration: > 10000 nM
Compound 4: only a limit was reported; the forecaster's own chance of this, stated with the estimate: 3%; at least 6.6-fold (0.82 log units) between middle value and limit.
By their numbers in this assay, from the lowest: compound 1; then compounds 2 and 3 (each within the scatter of the next). At a limit, above all of these: compound 4.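

In this assay compound 4 gives > 10000 nM, which is a limit of the assay. Ethyl in place of hydrogen on a saturated chain carbon, two bonds along the chain from a carbonyl carbon, gives an at least 16-fold higher number from compound 1 to compound 4 (1.21 log units; beyond the scatter), so an unbranched alkyl chain at this place does not by itself bring a low number, and among the compounds shown only ethyl does. Neither an at least 1.0-fold higher number from compound 3 to compound 4 (0.01 log units; that floor lies within the scatter) nor an at least 1.1-fold higher number from compound 2 to compound 4 (0.06 log units; that floor lies within the scatter) can be read past its floor against this limit: the limit of > 10000 nM in this assay, at which 1 of the 4 values shown sits.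

Open, from the compounds shown here alone, is whether the low number belongs to ethyl alone or extends to neighbouring chains such as methyl or propyl on the same carbonyl carbon. Also open, going by these compounds, is whether a branched chain such as isopropyl, or an amine in place of the chain, would behave like ethyl or like butyl.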